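This account rests on a few compounds, and the source may have more. Where it says the series, first, only, none or still open, it means among the compounds named here.

In a physicochemical assay for solubility, read by HPLC, in phosphate buffer, measured as kinetic solubility, at pH 7.4 (on this read-out higher numbers stand for higher solubility and lower numbers for lower solubility), compound 1 (`NS(=O)(=O)c1ccc(-c2cc(C(=O)C3CCC3)nn2-c2ccc(Cl)cc2)cc1`) gives 17200 nM with cyclobutyl on a carbonyl carbon. Among the measured compounds shown here, compound 2 (`NS(=O)(=O)c1ccc(-c2cc(C(=O)N3CCCC3)nn2-c2ccc(Cl)cc2)cc1`) gives 57900 nM and holds the higher of the two numbers so far. For the measured compounds named here, the only measured step is a 3.4-fold higher number from compound 1 to compound 2 (0.53 log units; beyond the scatter) and it comes with pyrrolidin-1-yl taking the place of cyclobutyl on that carbonyl carbon. Compound 3 (`CN(C(=O)c1cc(-c2ccc(S(N)(=O)=O)cc2)n(-c2ccc(Cl)cc2)n1)C1CC1`) has the same atoms as compound 2, joined differently, and cyclopropyl(methyl)amino in place of pyrrolidin-1-yl on a carbonyl carbon is the whole change. Going by the values given here, the measured step replaced cyclobutyl, which plays no part in this change, so it bears only loosely here, and no measured step tests this swap directly. No step beyond the usual scatter is therefore expected in this assay and no direction is favoured. The expected step is a 1.1-fold lower number from compound 2 to compound 3 (0.02 log units; within the scatter) on this estimate. For compound 3 the estimated value is 55000 nM within an expected range of 25000 nM to 110000 nM on this read-out.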

Compound 3, solubility: 99600 nM
Estimate against measurement, compound 3: 1.8-fold (0.26 log units) below; the range from low to high includes it.
By their numbers in this assay, from the lowest: compound 1; then compounds 2 and 3 (each within the scatter of the next).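

In this assay, the change of cyclopropyl(methyl)amino for pyrrolidin-1-yl on the carbonyl carbon gives a 1.7-fold higher number from compound 2 to compound 3 (0.24 log units; within the scatter), so swapping the five-membered ring for a three-membered ring plus a methyl, with the same heavy-atom count, produces no separable difference. Set against cyclobutyl, the same group gives a 5.8-fold higher number from compound 1 to compound 3 (0.76 log units; beyond the scatter), so two different groups joined through nitrogen to the carbonyl carbon now stand clear of cyclobutyl in this assay, and none of the three compounds goes against that. Nothing shown gives a measured reason for these numbers.

From the compounds shown here alone, whether the pattern extends to an open-chain group such as dimethylamino, or to a ring with a second hetero atom such as morpholin-4-yl, stays open. So does whether an amine without any carbon ring, the plain carboxamide, would fall with these two groups.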